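The source may hold more compounds than are shown below. What is called first, only, known or untested is meant among the compounds shown, and "the series" means these compounds.

Compound 1 `c1ccc(Cc2nnc(-c3c[nH]c4ccccc34)o2)cc1` — in a functional assay on DU-145 cells (Homo sapiens) for cytotoxicity, read by MTT assay (on this read-out higher numbers stand for weaker inhibition and lower numbers for stronger inhibition), compound 1 gives > 1000000 nM, a limit of the assay rather than a number.
Compound 2 `Clc1ccc(-c2nnc(-c3c[nH]c4ccccc34)o2)cc1` — in this assay compound 2 gives 192000 nM.

For the measured compounds named here, compound 2 thus holds the only true number in this assay; compound 1 sits at the limit (the limit of > 1000000 nM in this assay, at which 1 of the 2 values shown sits). Compound 3 `FC(F)(F)c1nnc(-c2c[nH]c3ccccc23)o1` differs from compound 2 by trifluoromethyl in place of 4-chlorophenyl on an aromatic carbon. Going by the values given here, the single measured step, an at least 5.2-fold lower number from compound 1 to compound 2 (0.71 log units; beyond the scatter), concerned a different exchange and so bears only loosely here; it does show that the shared core without the 4-chlorophenyl gave no measurable number. A weaker result is therefore expected for compound 3, estimated at 500000 nM, with a range from 120000 nM to 2000000 nM. This expected step is a 2.6-fold higher number from compound 2 to compound 3 (0.42 log units; beyond the scatter).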

Compound 3, half-maximal inhibitory concentration: > 1000000 nM
Compound 3: a limit, no number; the forecaster's own chance of this, stated with the estimate: 45%; at least 2.0-fold (0.30 log units) between middle value and limit.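

Replacing 4-chlorophenyl with trifluoromethyl on this aromatic carbon gives an at least 5.2-fold higher number from compound 2 to compound 3 (0.71 log units; beyond the scatter) in this assay. Of the three groups tried at this position, only 4-chlorophenyl gives a true number, while the other two compounds sit at a limit: the limit of > 1000000 nM in this assay, at which 2 of the 3 values shown sit. Compound 1 and compound 3 both stand at that limit, so the step between them cannot be read.

Going by these compounds, it remains open whether the chlorine or the six-membered aromatic ring matters more. A plain phenyl or a longer chain such as butyl at this position could help separate the two.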